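A Fluorine Added to the Benzamide of Compound 1

The compounds below may be only part of what the source reports. "The series", "measured", "known", "first", "only" and "open" are said of these compounds alone.

Compound 1 `O=C(NC/C=C\Cn1ccc(=O)[nH]c1=O)c1ccccc1` was tested in a functional assay on MIA PaCa-2 cells (Homo sapiens) for cytotoxicity, read by MTT assay, with a stated time of 72 h; a higher number here means a weaker inhibitor, a lower number a stronger inhibitor. In this assay compound 1 reaches only the assay limit, > 100000 nM. Compound 2 `O=C(NC/C=C\Cn1cc(C(F)(F)F)c(=O)[nH]c1=O)c1ccccc1` also sits at the limit in this assay, at > 100000 nM. The step that the two limits leave unreadable from compound 1 to compound 2 therefore cannot be read. Compound 3 `O=C(NC/C=C\Cn1ccc(=O)[nH]c1=O)c1ccc(F)cc1` differs from compound 1 by fluoro in place of hydrogen on an aromatic carbon. Among the measured compounds shown here, no measured step resembles this change, and the only guide is the limit of > 100000 nM in this assay, at which 2 of the 2 values shown sit. No step beyond the scatter is expected in this assay. Compound 3 is therefore estimated at 100000 nM, between 40000 nM and 300000 nM, most likely again reported as a limit. The expected step of a number no higher from compound 1 to compound 3 (the limit leaves the size open) is accordingly close to nothing.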

Compound 3, half-maximal inhibitory concentration: > 100000 nM
Compound 3: only a limit was reported; the forecaster's own chance of this, stated with the estimate: 85%; the middle value sits exactly at the limit.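

Among the compounds shown here, compound 1 and compound 3 both sit at the limit of this assay, so no step between them can be read. The compounds shown leave open which change to the shared core, if any, would give a readable value.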